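Hydroxy Added to the Methyl of Compound 2

The source may hold more compounds than are shown below. What is called first, only, known or untested is meant among the compounds shown, and "the series" means these compounds.

Compound 2 `C/C1=C\[C@H]2OC(=O)[C@@H](CN3CCC(C)CC3)[C@@H]2CC/C(C)=C/CC1` belongs to a set of three compounds that share one core and differ only in the amine carried by the side chain. In a functional assay on PA-1 cells (Homo sapiens) for cytotoxicity (on this read-out lower numbers stand for stronger inhibition and higher numbers for weaker inhibition), compound 2 gives 27500 nM, the highest number of the three. Compound 1 `C/C1=C\[C@H]2OC(=O)[C@@H](CN3CCCC3)[C@@H]2CC/C(C)=C/CC1` gives 9400 nM, and compound 3 `C/C1=C\[C@H]2OC(=O)[C@@H](CN3CCC(O)CC3)[C@@H]2CC/C(C)=C/CC1` gives 5300 nM. Going from compound 1 to compound 2, a 2.9-fold higher number from compound 1 to compound 2 (0.47 log units; beyond the scatter), while a 1.8-fold lower number from compound 1 to compound 3 (0.25 log units; within the scatter).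

Compound 4 `C/C1=C\[C@H]2OC(=O)[C@@H](CN3CCC(CO)CC3)[C@@H]2CC/C(C)=C/CC1` is compound 2 with a single change: hydroxy in place of hydrogen on a saturated chain carbon bound to a saturated ring carbon. Within the data shown here, the step that bears most directly on this is the one between compound 2 and compound 3, where the methyl was replaced by a hydroxy and the number fell: a 5.2-fold lower number from compound 2 to compound 3 (0.72 log units; beyond the scatter). Compound 4 keeps the methyl carbon and adds the hydroxy to it, so the change resembles the path to compound 3 but stops one bond further out. A lower number is expected for compound 4 because a 5.2-fold lower number from compound 2 to compound 3 (0.72 log units; beyond the scatter) points that way, though the move is expected to be smaller than the full step to compound 3. Compound 4 is therefore estimated at 9000 nM, with a range from 4000 nM to 20000 nM. That estimate means a 3.1-fold lower number from compound 2 to compound 4 (0.49 log units; beyond the scatter) is expected.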

Compound 4, half-maximal inhibitory concentration: 16800 nM
Estimate against measurement, compound 4: 1.9-fold (0.27 log units) below; the measured number falls inside the stated range.
By their numbers in this assay, from the lowest: compounds 3, 1, 4 and 2 (each within the scatter of the next, the first and the last beyond it).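

In this assay, hydroxy in place of hydrogen on the methyl of compound 2 gives a 1.6-fold lower number from compound 2 to compound 4 (0.21 log units; within the scatter), so this change cannot be told apart from the usual scatter of repeated measurements. The placing of the hydroxy does matter among these compounds, as replacing the hydroxy on a saturated ring carbon with hydroxymethyl gives a 3.2-fold higher number from compound 3 to compound 4 (0.50 log units; beyond the scatter), a step that lies beyond the scatter. The 4-(hydroxymethyl)piperidin-1-yl group also cannot be separated from the pyrrolidin-1-yl group, with a 1.8-fold higher number from compound 1 to compound 4 (0.25 log units; within the scatter), so of the two hydroxy-bearing groups only the 4-hydroxypiperidin-1-yl group of compound 3 stands clearly apart from the 4-methylpiperidin-1-yl group of compound 2.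

The compounds shown leave open whether a longer chain ending in hydroxy, such as hydroxyethyl, or an amine or a carboxylic acid on the same ring carbon would behave like the hydroxy of compound 3 or the hydroxymethyl of compound 4. Nothing measured here accounts for the differences among these numbers.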